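Chain in place of the small ring on compound 2

The source may report more compounds than this note shows. Statements on the series, on what has been measured and on what is new or still open speak of the compounds shown alone.

Compound 2 `[O-][S+]1CC(Nc2nonc2/C(=N/O)Nc2ccc(F)c(Br)c2)C1` gives 212 nM in an assay on isolated protein for inhibition of Indoleamine 2,3-dioxygenase 1 (Homo sapiens), read by fluorescence, with a stated time of 60 min (a higher number here means a weaker inhibitor, a lower number a stronger inhibitor), the highest of the numbers shown, yet within the scatter of both compound 3 `O=S(=O)(CCNc1nonc1/C(=N/O)Nc1ccc(F)c(Br)c1)N1CCC1` at 191 nM and compound 1 `NNc1nonc1/C(=N/O)Nc1ccc(F)c(Br)c1` at 108 nM. Compound 4 `CN(C)S(=O)(=O)CCCNc1nonc1/C(=N/O)Nc1ccc(F)c(Br)c1` differs from compound 2 by a group of 9 heavy atoms (5 carbon, 1 nitrogen, 2 oxygen, 1 sulfur; no ring) in place of a group of 5 heavy atoms (3 carbon, 1 oxygen, 1 sulfur; one four-membered non-aromatic ring with 1 hetero atom), on a nitrogen on an aromatic ring. The steps measured so far at this nitrogen are all small: a 2.0-fold higher number from compound 1 to compound 2 (0.29 log units; within the scatter), a 1.8-fold higher number from compound 1 to compound 3 (0.25 log units; within the scatter) and a 1.1-fold lower number from compound 2 to compound 3 (0.05 log units; within the scatter). Compound 3 already carries a sulfonyl chain in place of the ring and sits within the scatter of compound 2, so no step beyond the scatter is expected for compound 4 in this assay, a 1.1-fold lower number from compound 2 to compound 4 (0.05 log units; within the scatter). Compound 4 is therefore estimated at 190 nM, with a range of 90 nM to 400 nM.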

Compound 4, half-maximal inhibitory concentration: 97 nM
Estimate against measurement, compound 4: 2.0-fold (0.29 log units) above; the measured number falls inside the stated range.
By their numbers in this assay, from the lowest: compounds 4, 1, 3 and 2 (each within the scatter of the next, the first and the last beyond it).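

In this assay, for the compounds shown here, the 3-(dimethylsulfamoyl)propyl chain gives the first step at this nitrogen that lies beyond the scatter, though a modest one: a 2.2-fold lower number from compound 2 to compound 4 (0.34 log units; beyond the scatter). The other two steps stay within the scatter, a 2.0-fold lower number from compound 3 to compound 4 (0.29 log units; within the scatter) and a 1.1-fold lower number from compound 1 to compound 4 (0.05 log units; within the scatter), so this open chain and the amino group of compound 1 cannot be told apart here. No evidence accounts for the step from the ring to the chain.

Still open, going by these compounds, is whether a carboxylic acid or an amine in place of the dimethylsulfamoyl group, or a longer chain, would move the number beyond the scatter of compound 4.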